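Swapping a Benzothiazole Amide for a Pyridine Amide

The source may report more compounds than this note shows. Statements on the series, on what has been measured and on what is new or still open speak of the compounds shown alone.

Measured so far:
compound 1, `Cc1cnc(NC(=O)COc2ccc(/C=C3\SC(=O)NC3=O)cc2)s1`, 37200 nM; 2240 nM (2 entries)
compound 2, `O=C(COc1ccc(/C=C2\SC(=O)NC2=O)cc1)Nc1cccc(C(F)(F)F)c1`, 2510 nM
compound 3, `O=C(COc1ccc(/C=C2\SC(=O)NC2=O)cc1)Nc1nc2ccccc2s1`, 28200 nM

In a functional assay on PC-3 cells (Homo sapiens) for cytotoxicity, read by sulforhodamine B assay, with a stated time of 48 h (a lower number here means a stronger inhibitor of growth, a higher number a weaker inhibitor of growth), compound 3 gives 28200 nM, the highest of the two single numbers. Compound 2 gives 2510 nM, and the gap between these two lies well beyond the usual scatter. Compound 1 is harder to place, since the several entries of compound 1 in this assay, 37200 nM; 2240 nM (2 entries) spread widely.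

Compound 4, `O=C(COc1ccc(/C=C2\SC(=O)NC2=O)cc1)Nc1ccccn1`, differs from compound 3 in one place: pyridin-2-yl in place of 1,3-benzothiazol-2-yl on an amide-type nitrogen. For the measured compounds named here, no step between measured compounds shows this change directly, so its effect is uncertain. Given that compound 2, with a plain aryl group on the same nitrogen, gives 2510 nM, a moderate drop in the number toward that level is expected, the step of a 2.8-fold lower number from compound 3 to compound 4 (0.45 log units; beyond the scatter). Compound 4 is therefore estimated at 10000 nM, within 2000 nM to 50000 nM.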

Compound 4, concentration for 50% growth inhibition: 29500 nM
The estimate for compound 4 lay 3.0-fold (0.47 log units) below the measured number; low and high end bracket the measured number.
By their numbers in this assay, from the lowest: compound 2; then compounds 3 and 4 (each within the scatter of the next).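

In this assay, pyridin-2-yl in place of 1,3-benzothiazol-2-yl on the amide-type nitrogen gives a 1.0-fold higher number from compound 3 to compound 4 (0.02 log units; within the scatter). At this position, then, the two groups cannot be told apart, although pyridin-2-yl has fewer heavy atoms and lacks the sulfur-bearing five-membered aromatic ring. Nothing available here explains this result.

The compounds shown leave open what a non-aromatic group such as a cyclohexyl ring would do on this nitrogen. They also leave open whether a carboxylic acid or an amine added to pyridin-2-yl would move the number.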